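Replacing an Amino Ring Group with 1-Hydroxyethyl

The source may hold more compounds than are shown below. What is called first, only, known or untested is meant among the compounds shown, and "the series" means these compounds.

In an in vitro ADME assay on microsomes (Homo sapiens) for metabolic stability (on this read-out lower numbers stand for a shorter-lived compound and higher numbers for a longer-lived compound), compound 1 `Cc1c2c(n3c1CCN(C(=O)C1(N)CC1)C[C@@H](C)[C@H](C)Nc1cc-3ccc1C(N)=O)CC(C)(C)CC2=O` gives 0.0667 h. Compound 2 `Cc1c2c(n3c1CCN(C(=O)C1(N)CCCC1)C[C@@H](C)[C@H](C)Nc1cc-3ccc1C(N)=O)CC(C)(C)CC2=O` stands level with it, and compound 2 gives 0.0667 h. Both are short-lived on this measure. Compound 3 `Cc1c2c(n3c1CCN(C(=O)[C@H](C)O)C[C@@H](C)[C@H](C)Nc1cc-3ccc1C(N)=O)CC(C)(C)CC2=O` carries a new change: 1-hydroxyethyl in place of 1-aminocyclopentyl on a carbonyl carbon. In short, 1-hydroxyethyl sits in place of 1-aminocyclopentyl on a carbonyl carbon. Going by the values given here, only one measured step bears on this swap: no change at the digits printed from compound 1 to compound 2 (within the scatter). That step stayed within the normal spread of repeat measurements, even though the group on the carbonyl carbon was exchanged. It is only a loose guide, however, since both of its groups contain a ring and an amino group, whereas 1-hydroxyethyl has no ring. No step beyond the scatter is expected, and the estimated step is a 1.2-fold higher number from compound 2 to compound 3 (0.08 log units; within the scatter). Compound 3 is estimated at 0.08 h, with an expected range of 0.05 h to 0.25 h.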

Compound 3, half-life: 0.25 h
Compound 3: middle estimate off by 3.1-fold (0.49 log units), on the low side; the measured number falls inside the stated range.
By their numbers in this assay, from the lowest: compounds 1 and 2 (each within the scatter of the next); then compound 3.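

In this assay the group on this carbonyl carbon can clearly shift the number: the swap to 1-hydroxyethyl gives a 3.7-fold higher number from compound 2 to compound 3 (0.57 log units; beyond the scatter) and also a 3.7-fold higher number from compound 1 to compound 3 (0.57 log units; beyond the scatter) and so reaches beyond the scatter from both earlier compounds. Compounds 1 and 2 stood level, so exchanging one amino ring group for another had revealed no such sensitivity at this position. The new change removes the ring, exchanges the amino group for a hydroxyl group and shortens the group all at once, and no measurement here accounts for the step.

The compounds shown do not separate these changes. A 1-aminoethyl group would keep the open chain with the amino group, and a 1-hydroxycyclopropyl group would keep the ring with the hydroxyl group, so each could show which feature goes with the step.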